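Moving from 2,3-dimethylphenyl to 2,5-dimethylphenyl

A few compounds are considered here, and "the series" means these few. Any claim that something is new, unique, unknown or untested is made for them only; others in the source may bear on it.

In a functional assay on Jurkat cells (Homo sapiens) (on this read-out lower numbers stand for stronger inhibition and higher numbers for weaker inhibition), compound 1 (`C[C@H](NC(=O)C(=O)NCC1CCCCC1)C(=O)N[C@@H](CC(=O)O)C(=O)COc1c(F)c(F)cc(F)c1F`) gives 19 nM with cyclohexyl on a saturated chain carbon bound to an amide-type nitrogen. At the same place, compound 2 (`C[C@H](NC(=O)C(=O)NCc1cccc(F)c1)C(=O)N[C@@H](CC(=O)O)C(=O)COc1c(F)c(F)cc(F)c1F`) carries 3-fluorophenyl and gives 106 nM on this read-out. Compound 3 (`Cc1cccc(CNC(=O)C(=O)N[C@@H](C)C(=O)N[C@@H](CC(=O)O)C(=O)COc2c(F)c(F)cc(F)c2F)c1C`) carries 2,3-dimethylphenyl and gives 102 nM in the same measurement. Compound 3 lies within the scatter of compound 2, and both stand at clearly higher numbers than compound 1.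

Compound 4 (`Cc1ccc(C)c(CNC(=O)C(=O)N[C@@H](C)C(=O)N[C@@H](CC(=O)O)C(=O)COc2c(F)c(F)cc(F)c2F)c1`) has 2,5-dimethylphenyl in place of 2,3-dimethylphenyl on that same carbon (2,5-dimethylphenyl in place of 2,3-dimethylphenyl on a saturated chain carbon bound to an amide-type nitrogen), with the same atoms joined differently. Within the data shown here, no measured pair shows this kind of change directly. The nearest evidence is a 1.0-fold lower number from compound 2 to compound 3 (0.02 log units; within the scatter) between two aromatic groups. The larger steps, a 5.6-fold higher number from compound 1 to compound 2 (0.75 log units; beyond the scatter) and a 5.4-fold higher number from compound 1 to compound 3 (0.73 log units; beyond the scatter) both replace cyclohexyl with an aromatic group, which compound 4 does not do relative to compound 3. The expected step is a 1.0-fold lower number from compound 3 to compound 4 (0.01 log units; within the scatter) and it is estimated to stay within the scatter, with no direction favoured. In this assay the estimate for compound 4 is 100 nM with a range from 45 nM to 220 nM expected.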

Compound 4, half-maximal inhibitory concentration: 11 nM
Beside the measured number, compound 4's estimate is 9.1-fold (0.96 log units) above it, outside the stated range (below it).
By their numbers in this assay, from the lowest: compounds 4 and 1 (each within the scatter of the next); then compounds 3 and 2 (each within the scatter of the next).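

In this assay, among these compounds, the arrangement of the two methyl groups on the aromatic ring at this position changes the read-out strongly, a difference the earlier compounds gave no sign of: 2,5-dimethylphenyl in place of 2,3-dimethylphenyl gives a 9.3-fold lower number from compound 3 to compound 4 (0.97 log units; beyond the scatter), although the two groups have the same atoms, joined differently. Against the earlier pair of aromatic groups, which stayed within the scatter of each other, the same group gives a 9.6-fold lower number from compound 2 to compound 4 (0.98 log units; beyond the scatter) and a 1.7-fold lower number from compound 1 to compound 4 (0.24 log units; within the scatter), so compound 4 goes against the gap between cyclohexyl and the aromatic groups in compounds 2 and 3, and that gap cannot be read as holding for every aromatic group at this place. Nothing available here accounts for the effect of this rearrangement.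

The compounds shown leave open whether the result depends on the methyl groups themselves or would carry over to 2,5-dichlorophenyl or 2,5-dimethoxyphenyl at the same place. Also open, going by these compounds, is how 2,5-dimethylphenyl behaves on a longer chain in place of the saturated chain carbon bound to an amide-type nitrogen.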